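Removing a methoxy group from the ring-fused core of compound 2

A few compounds are considered here, and "the series" means these few. Any claim that something is new, unique, unknown or untested is made for them only; others in the source may bear on it.

Three compounds share a trimethoxyphenyl-pyrazole theme and were tested in a functional assay on MCF7 cells (Homo sapiens) for inhibition, read by MTT assay, with a stated time of 48 h; on this read-out lower numbers stand for stronger inhibition and higher numbers for weaker inhibition. Compound 1 `COc1cc(-c2cc(/C=C/C(=O)c3ccc(N)cc3)[nH]n2)cc(OC)c1OC` gives 1600 nM, compound 3 `COc1ccc(-c2cc(/C=C/C(=O)c3ccc(N)cc3)[nH]n2)cc1OC` gives 1900 nM, and compound 2 `COc1ccc2c(c1)C/C(=C\c1cc(-c3cc(OC)c(OC)c(OC)c3)n[nH]1)C2=O` gives 2100 nM; the difference between the core of compound 2 and that of compound 1 is not broken down here. Compound 3 arises from compound 1 by hydrogen in place of methoxy on an aromatic carbon and the step measured was a 1.2-fold higher number from compound 1 to compound 3 (0.07 log units; within the scatter). Compound 4 `COc1cc(-c2cc(/C=C3\Cc4ccccc4C3=O)[nH]n2)cc(OC)c1OC` is made from compound 2 by the same kind of change, (hydrogen in place of methoxy on an aromatic carbon), but here the place lies on a ring that is part of a fused system, meta and para to a fused ring, rather than ortho and meta to methoxy groups. Because a 1.2-fold higher number from compound 1 to compound 3 (0.07 log units; within the scatter) stayed within the scatter, a similar step a 1.1-fold higher number from compound 2 to compound 4 (0.06 log units; within the scatter) is expected, and compound 4 is estimated at 2400 nM, likely between 1200 nM and 5000 nM.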

Compound 4, half-maximal inhibitory concentration: 4800 nM
For compound 4 the middle estimate is 2.0-fold (0.30 log units) below the measured one; low and high end bracket the measured number.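

In this assay, swapping methoxy for hydrogen on the core of compound 2 gives a 2.3-fold higher number from compound 2 to compound 4 (0.36 log units; beyond the scatter), a modest step. Set beside the same swap on the other core, the two steps cannot be told apart, so as far as these two pairs go, the change carries across both cores: the same change on two cores in this assay, a 1.2-fold higher number (0.07 log units; within the scatter) from compound 1 to compound 3 and a 2.3-fold higher number (0.36 log units; beyond the scatter) from compound 2 to compound 4, 1.9-fold (0.28 log units) apart, within the scatter of two such steps. Two pairs are a small sample, however, and they show neither that the step would keep its size on a further core nor what lies behind either step.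

The compounds shown leave open how another group at that place on the core of compound 2, such as an amine or a longer chain like ethoxy, would compare with methoxy or hydrogen. They also leave open whether the step would hold on cells other than the ones used here.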